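A few compounds are considered here, and "the series" means these few. Any claim that something is new, unique, unknown or untested is made for them only; others in the source may bear on it.

Three compounds have been measured in a functional assay on UACC-62 cells (Homo sapiens) for inhibition, read by sulforhodamine B assay, with a stated time of 48 h; a higher number here means a weaker inhibitor of growth, a lower number a stronger inhibitor of growth:

Compound 1 `C=C(C)[C@@H]1CC=C(Cn2cc(COc3ccc(C4NC(=O)NC(C)=C4C(=O)OCC)cc3)nn2)CC1` gives 19200 nM.
Compound 2 `C=C(C)[C@@H]1CC=C(Cn2cc(COc3cccc(C4NC(=O)NC(C)=C4C(=O)OCC)c3)nn2)CC1` gives 22900 nM.
Compound 3 `C=C(C)[C@@H]1CC=C(Cn2cc(COc3ccc(C4NC(=O)NC(C)=C4C(C)=O)cc3)nn2)CC1` gives 20500 nM.

Compound 1 and compound 3 share one core and differ in a single place: methyl in place of ethoxy on a carbonyl carbon. That change made a 1.1-fold higher number from compound 1 to compound 3 (0.03 log units; within the scatter). Compound 2 is built from the same atoms as compound 1, joined differently; the difference between the two cores is not broken down here. Compound 2 gives the highest of the three numbers, but its gaps to compound 3 and to compound 1 are both within the scatter, so the three compounds cannot be placed in any order of potency against each other.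

Compound 4 `C=C(C)[C@@H]1CC=C(Cn2cc(COc3cccc(C4NC(=O)NC(C)=C4C(C)=O)c3)nn2)CC1` has not yet been measured in this assay. It stands to compound 2 as compound 3 stands to compound 1: methyl in place of ethoxy on a carbonyl carbon. The place of the change is described in the same words in both cases, so this is the same change carried onto the core of compound 2. The expectation for compound 4 rests on one earlier example only, namely a 1.1-fold higher number from compound 1 to compound 3 (0.03 log units; within the scatter), which lay within the scatter. On that basis the expected step is a 1.0-fold higher number from compound 2 to compound 4 (0.02 log units; within the scatter). Compound 4 is therefore expected to give about 24000 nM, with an estimated range from 12000 nM to 48000 nM.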

Compound 4, concentration for total growth inhibition: 31600 nM
Compound 4: middle estimate off by 1.3-fold (0.12 log units), on the low side, within the range that was stated.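

Carried onto the other core, the change from ethoxycarbonyl to acetyl gave a 1.4-fold higher number from compound 2 to compound 4 (0.14 log units; within the scatter) in this assay. Set beside the earlier example, the two steps cannot be told apart, so the cores do not separate in their response to this change: the same change on two cores in this assay, a 1.1-fold higher number (0.03 log units; within the scatter) from compound 1 to compound 3 and a 1.4-fold higher number (0.14 log units; within the scatter) from compound 2 to compound 4, 1.3-fold (0.11 log units) apart, within the scatter of two such steps. Going by these compounds alone, this shows that, in both of the pairs available, methyl in place of ethoxy on this carbonyl carbon left the number within the scatter, so the change carried from one core to the other without any step that can be distinguished from repeat measurement, but with only two pairs it does not show that the same would hold on any further core, and it does not establish that the two steps are identical.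

All four compounds carry either ethoxy or methyl on this carbonyl carbon, so they leave open how a carboxylic acid, an amide or a longer chain such as butoxy would read at the same place. From the compounds shown here alone, whether the change would behave in the same way on a core carrying a further group, such as an amine or a fluorine atom, also remains open.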